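A few compounds are considered here, and "the series" means these few. Any claim that something is new, unique, unknown or untested is made for them only; others in the source may bear on it.

Measured so far in one test:
compound 1, `CCN(CC)CN1C(=O)/C(=N/NC(=S)Nc2ccc(Cl)cc2)c2ccccc21`: 400 nM
compound 2, `CCN(CC)CN1C(=O)/C(=N/NC(=S)Nc2ccc(C)cc2)c2ccccc21`: 200 nM
compound 3, `CCN(CC)CN1C(=O)/C(=N/NC(=S)Nc2ccc(C)cc2)c2cc(Cl)ccc21`: 11300 nM

All three were run in an ADME assay on MDCK cells (Canis lupus familiaris) for cytotoxicity; on this read-out higher numbers stand for lower toxicity in this test and lower numbers for higher toxicity in this test. Compound 3 differs from compound 2 in its core, by chloro in place of hydrogen on an aromatic carbon; this single change gave a 57-fold higher number from compound 2 to compound 3 (1.75 log units; beyond the scatter). Compound 1 differs from compound 2 on the outer ring, by chloro in place of methyl on an aromatic carbon, and this gave a 2.0-fold higher number from compound 2 to compound 1 (0.30 log units; within the scatter).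

Compound 4, `CCN(CC)CN1C(=O)/C(=N/NC(=S)Nc2ccc(Cl)cc2)c2cc(Cl)ccc21`, has not yet been measured. It stands to compound 3 exactly as compound 1 stands to compound 2: it differs by chloro in place of methyl on an aromatic carbon, the same change at the same place. Since that change moved the number only a little the first time, a similarly small step is expected from compound 3 to compound 4 in this assay, a 1.4-fold higher number from compound 3 to compound 4 (0.15 log units; within the scatter), resting on the earlier step of a 2.0-fold higher number from compound 2 to compound 1 (0.30 log units; within the scatter) and starting from the value of compound 3, 11300 nM. Compound 4 is therefore estimated at 16000 nM, expected to lie between 5000 nM and 50000 nM.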

Compound 4, half-maximal cytotoxic concentration: 2400 nM
For compound 4 the middle estimate is 6.7-fold (0.82 log units) above the measured one; measured number below the stated range.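

In this assay, replacing methyl with chloro on the outer ring does not carry over from one core to the other: the core bearing chloro gives a 4.7-fold lower number from compound 3 to compound 4 (0.67 log units; beyond the scatter) and so departs from the earlier step on the core without it: the same change on two cores in this assay, a 2.0-fold higher number (0.30 log units; within the scatter) from compound 2 to compound 1 and a 4.7-fold lower number (0.67 log units; beyond the scatter) from compound 3 to compound 4, 9.4-fold (0.97 log units) apart, beyond the scatter of two such steps.

Seen from the other side, adding chloro to the core gives a 6.0-fold higher number from compound 1 to compound 4 (0.78 log units; beyond the scatter) when the outer ring is 4-chlorophenyl, and this rise is smaller than the one seen with 4-methylphenyl: the same change on two cores in this assay, a 57-fold higher number (1.75 log units; beyond the scatter) from compound 2 to compound 3 and a 6.0-fold higher number (0.78 log units; beyond the scatter) from compound 1 to compound 4, 9.4-fold (0.97 log units) apart, beyond the scatter of two such steps.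

In these four compounds, then, the effect of each change depends on the other, but this single set does not show why this happens, or whether it would hold for other groups.

The compounds shown leave open whether a fluoro or methoxy group on the outer ring would behave more like methyl or like chloro. They also leave open whether a morpholine in place of the diethylamine would alter this dependence.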